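Anilide to hexylamide on the quinoline acid series

A few compounds are considered here, and "the series" means these few. Any claim that something is new, unique, unknown or untested is made for them only; others in the source may bear on it.

Measured so far in a physicochemical assay for lipophilicity, using the shake flask method, in phosphate buffer, measured as octanol-water partition, at pH 7.4; on this read-out lower numbers stand for lower lipophilicity and higher numbers for higher lipophilicity:
compound 1, `COc1cc(-c2cc(C(=O)O)c3ccccc3n2)ccc1OCC(=O)Nc1cccc(F)c1`, 1.6
compound 2, `COc1cc(-c2cc(C(=O)O)c3ccccc3n2)ccc1OCC(=O)Nc1ccc(F)cc1`, 1.1
compound 3, `COc1cc(-c2cc(C(=O)O)c3ccccc3n2)ccc1OCC(=O)NCc1ccccc1`, 0.4

Compound 2 stands second highest of the three in this assay, above compound 3 and below compound 1. The step of a number 0.50 log units lower from compound 1 to compound 2 (beyond the scatter) is beyond the scatter, as is a number 0.70 log units lower from compound 2 to compound 3 (beyond the scatter) and the larger a number 1.20 log units lower from compound 1 to compound 3 (beyond the scatter).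

Compound 4, `CCCCCCNC(=O)COc1ccc(-c2cc(C(=O)O)c3ccccc3n2)cc1OC`, is not yet measured. Its difference from compound 2: hexyl in place of 4-fluorophenyl on an amide-type nitrogen.

Within the data shown here, no measured step replaces an aryl group on the amide nitrogen with a chain, so none bears directly on this change. The step of a number 0.70 log units lower from compound 2 to compound 3 (beyond the scatter) shows that leaving the 4-fluorophenyl for benzyl lowered the number, but a hexyl chain is not a benzyl group, and the measured compounds give no anchor for it. The expectation therefore rests weakly on the data: a modest step upward is expected, a number 0.40 log units higher from compound 2 to compound 4 (beyond the scatter), with a wide range. Compound 4 is estimated at 1.5 in this assay, between 0.7 and 2.3.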

Compound 4, distribution coefficient: 1
Compound 4: middle estimate off by 0.50 log units, on the high side, within the range that was stated.
By their numbers in this assay, from the lowest: compound 3; then compounds 4 and 2 (each within the scatter of the next); then compound 1.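

In this assay, among these compounds, the hexyl chain is the first group without a ring on the amide-type nitrogen, and with a number 0.10 log units lower from compound 2 to compound 4 (within the scatter) the six-membered aromatic ring of compound 2 gives way to this chain without a step that can be told from the scatter. Set against a number 0.60 log units higher from compound 3 to compound 4 (beyond the scatter) and a number 0.60 log units lower from compound 1 to compound 4 (beyond the scatter) the same chain stands apart from both benzyl and 3-fluorophenyl, so among these four compounds the presence or absence of a ring does not by itself order the numbers at this position. No measurement on hand accounts for any of these steps.

On these data alone, whether a shorter butyl chain or a longer octyl chain would stay within the scatter of compound 4 remains open. Also open, as far as these compounds go, is what a terminal amine or a terminal hydroxyl on the hexyl chain would do to the number.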